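Cyclohexyl in Place of Propyl on the Amide Nitrogen

A few compounds are considered here, and "the series" means these few. Any claim that something is new, unique, unknown or untested is made for them only; others in the source may bear on it.

Three measured compounds share one core and differ only in the group on the amide nitrogen. Compound 1 `CNC(=O)CC1CCc2cc(OC)c(OC)cc21` carries a methyl there, compound 2 `CCCNC(=O)CC1CCc2cc(OC)c(OC)cc21` a propyl, and compound 3 `COc1cc2c(cc1OC)C(CC(=O)NC1CCCC1)CC2` a cyclopentyl. In a functional assay on the whole organism (strain Wistar) for inhibition, with Rattus norvegicus as the target, read by paw edema, with stated times of 60 min and 3 h, at a dose of 100 mg/kg by the oral route (on this read-out higher numbers stand for more inhibition at the one dose given (going by the name of the read-out) and lower numbers for less inhibition), compound 1 gives 29%, compound 2 gives 29%, and compound 3 gives 43.5%. Compound 2 thus stands level with compound 1, the two together the lowest of the three, and the step of a number 14.5 percentage points higher from compound 2 to compound 3 (beyond the scatter) separates it from compound 3.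

Compound 4 `COc1cc2c(cc1OC)C(CC(=O)NC1CCCCC1)CC2` has not been measured. Its difference from compound 2 is cyclohexyl in place of propyl on an amide-type nitrogen. Two kinds of step bear on this. The step of no change at the digits printed from compound 1 to compound 2 (within the scatter) shows that a longer open chain on that nitrogen alters nothing, while a number 14.5 percentage points higher from compound 1 to compound 3 (beyond the scatter) and a number 14.5 percentage points higher from compound 2 to compound 3 (beyond the scatter) show that a five-membered ring in the same place brings a modest rise. Going by the values given here, a six-membered ring is the nearest change to that last one, so a rise of similar size is expected for compound 4, though with only three compounds the ground is thin. The estimate is that compound 4 will show 42% in this assay, with a range from 28% to 56%. The expected step is therefore a number 13 percentage points higher from compound 2 to compound 4 (beyond the scatter).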

Compound 4, a percentage reported as inhibition, in the whole organism at one dose (the size of the read-out at that dose, not a potency): 49.3%
Compound 4: middle estimate off by 7.3 percentage points, on the low side; low and high end bracket the measured number.
By their numbers in this assay, from the lowest: compounds 1 and 2 (each within the scatter of the next); then compounds 3 and 4 (each within the scatter of the next).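

In this assay the cyclohexyl group on the amide-type nitrogen gives a number 20.3 percentage points higher from compound 2 to compound 4 (beyond the scatter) and a number 20.3 percentage points higher from compound 1 to compound 4 (beyond the scatter) against the two open-chain compounds, so the rise seen with cyclopentyl now appears with a second ring. Among the four compounds, the two carrying a carbon ring on this nitrogen stand clear of the two carrying methyl or propyl, and no compound goes against that split. The size of the ring makes no readable difference, since the step is a number 5.8 percentage points higher from compound 3 to compound 4 (within the scatter) and two rings that sit level show no trend with ring size. No measurement is at hand that explains why the ring compounds differ from the open-chain ones.

The compounds shown cannot separate the ring itself from the larger number of carbons, as propyl, cyclopentyl and cyclohexyl also differ in carbon count, and an open hexyl chain on the same nitrogen would address that. As far as these compounds go, it also remains open how the read-out would respond to a flat phenyl ring, to a larger cycloheptyl ring, or to a ring holding an amine.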